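The source may report more compounds than this note shows. Statements on the series, on what has been measured and on what is new or still open speak of the compounds shown alone.

Compounds measured in a physicochemical assay for acid dissociation, read by capillary electrophoresis, tested at 100 uM:
compound 1, `O=c1c(O)c(NCc2ccccc2)c1=O` — < 2
compound 2, `CN(C)S(=O)(=O)NC(=O)CCc1ccccc1` — 5.86
compound 3, `O=S(O)CCc1ccccc1` — 2.1

Three compounds have been examined in this assay. Compound 1 gives < 2, which is a limit of the assay and not a number; it is the limit of < 2 in this assay, at which 1 of the 3 values shown sits. Of the two compounds that give numbers, compound 2 stands higher, at 5.86, while compound 3 gives 2.1, and the gap between them lies beyond the usual scatter.

The next compound to be measured is compound 4, `CS(=O)(=O)NC(=O)CCc1ccccc1`. It differs from compound 2 in one place: methyl in place of dimethylamino on a sulfonyl sulfur. Among the measured compounds shown here, no pair of measured compounds differing in only one place is available, so nothing measured here speaks directly to what such a change does, and the expectation below rests on the value of compound 2 alone.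

For compound 4 the step from the value of compound 2 is expected to be a number 1.16 log units lower from compound 2 to compound 4 (beyond the scatter), a move of moderate size downward. Compound 4 is thus estimated to give 4.7, with a likely range from 4 to 5.4.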

Compound 4, acid dissociation constant: 4.94
For compound 4 the middle estimate is 0.24 log units below the measured one, within the range that was stated.
By their numbers in this assay, from the lowest: compound 3; then compound 4; then compound 2. At a limit, below all of these: compound 1.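

In this assay, among the compounds shown here, the exchange of dimethylamino for methyl on a sulfonyl sulfur whose other neighbours are an amide-type nitrogen now has a measured size, the one step that can be read in this set: a number 0.92 log units lower from compound 2 to compound 4 (beyond the scatter). For the compounds shown here, compound 2 and compound 4 differ in this one place and share the rest of their structure, so the step belongs to this exchange alone and shows that the read-out responds to the group at this position, which the earlier compounds, differing from one another in more than one place, could not show. Nothing among the measurements shown gives a reason for the step, so it stands as an observed difference and no more.

A single pair gives one size and one direction, and it leaves open where other groups on the same sulfonyl sulfur would fall, such as ethyl, trifluoromethyl, a phenyl ring or an unsubstituted amine. Going by these compounds alone, it also leaves open whether the same exchange would give a step of similar size on a longer chain or on a core other than the one shared by compound 2 and compound 4.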